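The source may hold more compounds than are shown below. What is called first, only, known or untested is meant among the compounds shown, and "the series" means these compounds.

Measured compounds:
- compound 1 `Cc1ccc(C2C(C#N)=C(N)N(c3ccc(S(N)(=O)=O)cc3)C3=C2CCCC3)cc1`: in a functional assay on Ehrlich cells (Mus musculus) for cytotoxicity, read by trypan blue exclusion, with a stated time of 2 h, tested at 25 ug/mL (on this read-out higher numbers stand for a stronger effect at the one concentration tested and lower numbers for a weaker effect), compound 1 gives 30%
- compound 2 `N#CC1=C(N)N(c2ccc(S(N)(=O)=O)cc2)C2=C(CCCC2)C1c1ccc([N+](=O)[O-])cc1`: in this assay compound 2 gives 5%
- compound 3 `N#CC1=C(N)N(c2ccc(S(N)(=O)=O)cc2)C2=C(CCCC2)C1c1ccccc1Cl`: in this assay compound 3 gives 0%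

Among these three, compound 1 stands highest in this assay: compound 2 is nearest with a number 25 percentage points lower from compound 1 to compound 2 (beyond the scatter), and compound 3 is furthest with a number 30 percentage points lower from compound 1 to compound 3 (beyond the scatter). Between compound 2 and compound 3 the numbers hardly differ, a number 5 percentage points lower from compound 2 to compound 3 (within the scatter).

Compound 4 `N#CC1=C(N)N(c2ccc(S(N)(=O)=O)cc2)C2=C(CCCC2)C1c1ccc(Cl)cc1Cl` has not yet been measured. It differs from compound 1 in one place: 2,4-dichlorophenyl in place of 4-methylphenyl on a saturated ring carbon. The closest measured comparison is the step to compound 3, where a chlorine-bearing phenyl also replaced the 4-methylphenyl on the same saturated ring carbon and the number fell by a number 30 percentage points lower from compound 1 to compound 3 (beyond the scatter). The step to compound 2, another exchange on that aryl group, went the same way with a number 25 percentage points lower from compound 1 to compound 2 (beyond the scatter). Both replacements of the 4-methylphenyl lowered the read-out beyond the scatter, so a drop of similar size is expected for compound 4, a number 27 percentage points lower from compound 1 to compound 4 (beyond the scatter). Compound 4 is therefore estimated to give 3% in this assay, expected to lie between 0% and 20%.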

Compound 4, a percentage reported as activity, at one concentration (the size of the read-out at that concentration, not a potency): 50%
Estimate against measurement, compound 4: 47 percentage points below; the whole stated range lies below it.
By their numbers in this assay, from the lowest: compounds 3 and 2 (each within the scatter of the next); then compound 1; then compound 4.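

In this assay, chloro in place of hydrogen on an aromatic carbon gives a number 50 percentage points higher from compound 3 to compound 4 (beyond the scatter), so one added atom on this aryl group can separate a near-silent compound from the highest number in the set. The aryl group on this saturated ring carbon can therefore raise the read-out as well as lower it: 2,4-dichlorophenyl gives a number 20 percentage points higher from compound 1 to compound 4 (beyond the scatter) against 4-methylphenyl and a number 45 percentage points higher from compound 2 to compound 4 (beyond the scatter) against 4-nitrophenyl. A chlorine on this phenyl does not by itself mean a low number, since compound 3 and compound 4 both carry one, and no measurement here explains these steps.

On these data alone, it remains open whether 4-chlorophenyl alone would keep the higher read-out or whether both chlorines are needed. As far as these compounds go, how a 4-aminophenyl or 4-methoxyphenyl group would behave at this carbon also remains open.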